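The source may hold more compounds than are shown below. What is called first, only, known or untested is meant among the compounds shown, and "the series" means these compounds.

Compound 1 `CCOC(=O)c1ccc(NC(=O)C(=O)c2ccccc2NC(C)=O)cc1` belongs to a small set of three close relatives. In an assay on mitochondria from brain for inhibition of Amine oxidase [flavin-containing] B (Bos taurus) (on this read-out lower numbers stand for stronger inhibition and higher numbers for weaker inhibition), compound 1 gives 990000 nM. Compound 2 `COC(=O)CCNC(=O)C(=O)c1ccccc1NC(C)=O` gives 990000 nM, and compound 3 `COC(=O)CCCCCNC(=O)C(=O)c1ccccc1NC(C)=O` gives 590000 nM. Compound 1 therefore stands level with compound 2, the two together forming the highest numbers of the three, while compound 3 sits only a little lower, with a gap that stays within the usual scatter. Going by the values given here, the single measured step between neighbours, a 1.7-fold lower number from compound 2 to compound 3 (0.22 log units; within the scatter), replaces a short ester-bearing chain with a longer one and also stays within the scatter.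

Compound 4 `COC(=O)[C@@H](NC(=O)c1ccc(NC(=O)C(=O)c2ccccc2NC(C)=O)cc1)C(C)C` is now considered. The change from compound 1 is (1-(methoxycarbonyl)-2-methylpropyl)amino in place of ethoxy on a carbonyl carbon. Among the compounds with values here, no measured step concerns an exchange of this kind, and the one step that exists hardly moved the number. Given how closely all three measured values sit together, compound 4 is expected to land near compound 1, an estimated step of a 1.2-fold lower number from compound 1 to compound 4 (0.09 log units; within the scatter). The estimate for compound 4 in this assay is 800000 nM, with a range from 250000 nM to 2500000 nM.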

Compound 4, half-maximal inhibitory concentration: 430000 nM
Compound 4: middle estimate off by 1.9-fold (0.27 log units), on the high side, within the range that was stated.
By their numbers in this assay, from the lowest: compounds 4, 3, 1 and 2 (each within the scatter of the next, the first and the last beyond it).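

In this assay, (1-(methoxycarbonyl)-2-methylpropyl)amino in place of ethoxy on a carbonyl carbon gives a 2.3-fold lower number from compound 1 to compound 4 (0.36 log units; beyond the scatter), a modest change, but the first one in this small set to pass beyond the scatter. This position therefore accepts a group of 9 heavy atoms instead of 3, bringing a hydrogen-bond donor and a defined stereocentre, and the number does not rise, although compound 4 still gives 430000 nM on a read-out where lower numbers mean stronger inhibition. No measurement shown here accounts for the step.

Going by these compounds, it stays open whether the whole new group matters or only a part of it, such as the simple amide nitrogen or the branched isopropyl side chain. A carboxylic acid in place of the methyl ester, or the opposite configuration at the stereocentre, would help separate these parts.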